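The compounds below may be only part of what the source reports. "The series", "measured", "known", "first", "only" and "open" are said of these compounds alone.

In an ADME assay on L1210/0 cells (Mus musculus) for cytotoxicity, with a stated time of 48 h (on this read-out higher numbers stand for weaker inhibition and lower numbers for stronger inhibition), compound 1 (`C=Cc1cn([C@H]2C[C@H](O)[C@@H](CO)O2)c(=O)[nH]c1=O`), which carries a vinyl group on the shared core, gives 14200 nM as its measured value. Compound 2 (`CCCC#Cc1cn([C@H]2C[C@H](O)[C@@H](CO)O2)c(=O)[nH]c1=O`) is reported only as a limit (> 200000 nM) and not as an exact number. Among the measured compounds shown here, the one measured step that bears on the next change is large and lies beyond the scatter (an at least 14-fold higher number from compound 1 to compound 2 (1.14 log units; beyond the scatter)), with pent-1-yn-1-yl in place of vinyl on an aromatic carbon. Compound 3 (`CCCC/C=C\c1cn([C@H]2C[C@H](O)[C@@H](CO)O2)c(=O)[nH]c1=O`) changes this same group again, with hex-1-en-1-yl in place of pent-1-yn-1-yl on an aromatic carbon. Like the vinyl group of compound 1, the new chain holds a double bond outside aromatic rings, but it is closer in size to the pent-1-yn-1-yl chain that came with the large step (an at least 14-fold higher number from compound 1 to compound 2 (1.14 log units; beyond the scatter)). Inhibition in this assay is therefore expected to stay weak, with at most a modest move toward a lower number. The estimated step is small beside the earlier one (an at least 1.6-fold lower number from compound 2 to compound 3 (0.22 log units; that floor lies within the scatter)). For compound 3 the expected value is 120000 nM as a middle estimate (estimated range 40000 nM to 300000 nM).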

Compound 3, half-maximal inhibitory concentration: > 200000 nM
Compound 3: a limit, no number; the forecaster's own chance of this, stated with the estimate: 40%; at least 1.6-fold (0.22 log units) between middle value and limit.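

Replacing the vinyl group with hex-1-en-1-yl on an aromatic carbon gives an at least 14-fold higher number from compound 1 to compound 3 (1.14 log units; beyond the scatter) in this assay and so shows that a double bond outside aromatic rings does not, by itself, keep a compound at the level of compound 1. Together with the earlier step from vinyl to pent-1-yn-1-yl, this means that one longer chain with a triple bond and one longer chain with a double bond both lie well on the weak side of compound 1, so for these three compounds the type of unsaturated bond does not separate the result. Compound 3 is reported only as a limit, as compound 2 is, so the step between them cannot be read and the two longer chains cannot be ranked: the limit of > 200000 nM in this assay, at which 2 of the 3 values shown sit.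

The compounds shown do not tell where between the vinyl group and these longer chains the weakening sets in, which a prop-1-en-1-yl or but-1-en-1-yl group at the same position could help to locate. They also leave open how a saturated chain such as ethyl or hexyl, or a chain ending in an amine or a carboxylic acid, would read at this position.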